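Compound 1 to compound 4: oxan-4-yl for 4-hydroxycyclohexyl

The source may report more compounds than this note shows. Statements on the series, on what has been measured and on what is new or still open speak of the compounds shown alone.

- Compound 1 `N#Cc1cnc(NCc2cnccc2C(F)(F)F)cc1N[C@H]1CC[C@@H](O)CC1` gives 33%
- Compound 2 `N#Cc1cnc(NCc2ccccc2C(F)(F)F)cc1N[C@H]1CC[C@@H](O)CC1` gives 0%
- Compound 3 `N#Cc1cnc(NCc2cnccc2C(F)(F)F)cc1NC[C@H]1CC[C@@H](O)CC1` gives 41%
- Compound 4 `N#Cc1cnc(NCc2cnccc2C(F)(F)F)cc1NC1CCOCC1` has no measurement yet

All values come from an ADME assay on S9 fraction from liver (Homo sapiens) for metabolic stability, with a stated time of 1 h (a lower number here means that less of the compound is left, a higher number that more of the compound is left), and from no other test. Compound 1 at 33% lies within the scatter of compound 3 and beyond the scatter above compound 2. The next step is oxan-4-yl in place of 4-hydroxycyclohexyl on a nitrogen on an aromatic ring and leaves the rest of the core of compound 1 untouched. Going by the values given here, no measured compound carries oxan-4-yl, so direct evidence is missing. One measured step changes the same place: a number 8 percentage points higher from compound 1 to compound 3 (within the scatter) with (4-hydroxycyclohexyl)methyl in place of 4-hydroxycyclohexyl. Compound 2 differs elsewhere and says nothing about this place. Given a number 8 percentage points higher from compound 1 to compound 3 (within the scatter) as the only guide, no step beyond the scatter is expected, and the direction stays open. The estimated step is a number 5 percentage points higher from compound 1 to compound 4 (within the scatter) and should not be read as a real shift. Compound 4 is expected at 38% within an estimated range of 15% to 60% in this assay when measured.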

Compound 4, percent of the compound remaining: 91%
Compound 4: middle estimate off by 53 percentage points, on the low side, and the stated range ends below it.
By their numbers in this assay, from the lowest: compound 2; then compounds 1 and 3 (each within the scatter of the next); then compound 4.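

Oxan-4-yl in place of 4-hydroxycyclohexyl on a nitrogen on an aromatic ring gives a number 58 percentage points higher from compound 1 to compound 4 (beyond the scatter) in this assay, so this position is not indifferent to the group it carries, although compound 1 and compound 3 could not be told apart there. Oxan-4-yl in place of (4-hydroxycyclohexyl)methyl gives a number 50 percentage points higher from compound 3 to compound 4 (beyond the scatter), so the large step holds against both hydroxyl-bearing groups shown. No measurement at hand ties the step to a property of either group.

The change removes the hydroxyl and puts an oxygen into the ring in a single step, and the compounds shown do not separate these two differences. Open too, on these data alone, is how a 4-methoxycyclohexyl or a piperidin-4-yl group on the same nitrogen would read in this assay.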